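From cyclohexylamino to 3-methylpiperidin-1-yl in compound 4

The source may hold more compounds than are shown below. What is called first, only, known or untested is meant among the compounds shown, and "the series" means these compounds.

In a functional assay on HepG2 cells (Homo sapiens) for cytotoxicity, read by MTT assay, with a stated time of 48 h (on this read-out higher numbers stand for weaker inhibition and lower numbers for stronger inhibition), three compounds have been measured.
- compound 1 `O=C(c1ccccc1)N1N=C(c2cc3ccccc3oc2=O)CC1c1ccccc1` gives 36600 nM
- compound 2 `O=C(c1ccccc1Cl)N1N=C(c2cc3ccccc3oc2=O)CC1c1ccccc1` gives 5440 nM
- compound 3 `O=C(CNC1CCCCC1)N1N=C(c2cc3ccccc3oc2=O)CC1c1ccccc1` gives 34400 nM

At the upper end of these numbers sit two compounds, and the gap between them is a 1.1-fold lower number from compound 1 to compound 3 (0.03 log units; within the scatter) on this read-out. Compound 3 is thus one of that pair. The lowest number belongs to compound 2, and the way back up is a 6.3-fold higher number from compound 2 to compound 3 (0.80 log units; beyond the scatter) in the same measurement. The remaining step, a 6.7-fold lower number from compound 1 to compound 2 (0.83 log units; beyond the scatter) on an aromatic carbon, concerns a chloro group that compound 4 does not carry.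

Compound 4 `CC1CCCN(CC(=O)N2N=C(c3cc4ccccc4oc3=O)CC2c2ccccc2)C1` keeps everything else, and 3-methylpiperidin-1-yl in place of cyclohexylamino on a saturated chain carbon bound to a carbonyl carbon is the whole structural change. The two have the same atoms, joined differently. Going by the values given here, no measured step tests this exchange directly. The closest evidence is the replacement of phenyl by (cyclohexylamino)methyl on a carbonyl carbon, which stayed within the scatter as a 1.1-fold lower number from compound 1 to compound 3 (0.03 log units; within the scatter) in that comparison. No step beyond the scatter is therefore expected in this assay here, although the modest steps elsewhere leave room on either side. The expected step is a 1.1-fold lower number from compound 3 to compound 4 (0.06 log units; within the scatter) by this estimate. The estimate for compound 4 is 30000 nM and its expected range runs from 13000 nM to 75000 nM on the same read-out.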

Compound 4, half-maximal inhibitory concentration: "not active" (no number reported)
Compound 4: no number reported; the estimate stays without a comparison.
By their numbers in this assay, from the lowest: compound 2; then compounds 3 and 1 (each within the scatter of the next).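

In this assay, going by these compounds alone, compound 4 is reported as not active, without a number, so no step from compound 3 or any other compound to compound 4 can be read. The compounds shown leave open how 3-methylpiperidin-1-yl in place of cyclohexylamino shifts this read-out, if it shifts it at all. No supporting evidence bears on this result.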